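Vinyl in place of maleimide on the bis-trifluoromethylphenyl core

A few compounds are considered here, and "the series" means these few. Any claim that something is new, unique, unknown or untested is made for them only; others in the source may bear on it.

Measured in an ADME assay for pharmacokinetics, read by LC-MS, in phosphate buffer, with a stated time of 72 h, at pH 7.4, tested at 250 uM; a lower number here means that the compound disappears faster, a higher number that the compound lasts longer:
compound 1 `C=CC(=O)Oc1cc(C(F)(F)F)cc(C(F)(F)F)c1`: < 0.017 h (a limit of the assay)
compound 2 `O=C1C=CC(=O)N1c1cc(C(F)(F)F)cc(C(F)(F)F)c1`: < 0.017 h (a limit of the assay)

Compound 2 gives only a limit in this assay, < 0.017 h. Among the measured compounds shown here, the one measured step, a step that the two limits leave unreadable from compound 1 to compound 2, cannot be read because of the limit of < 0.017 h in this assay, at which 2 of the 2 values shown sit. Compound 3 `C=Cc1cc(C(F)(F)F)cc(C(F)(F)F)c1` differs from compound 2 by a group of 2 heavy atoms (2 carbon; no ring) in place of a group of 7 heavy atoms (4 carbon, 1 nitrogen, 2 oxygen; one five-membered non-aromatic ring with 1 hetero atom), on an aromatic carbon. For the measured compounds named here, no measured step covers this change, so the direction and size of the step cannot be taken from the data. The half-life of compound 3 in this assay is estimated at 20 h, within 1 h to 72 h. This estimate means a step of an at least 1100-fold higher number from compound 2 to compound 3 (3.07 log units; beyond the scatter), held with wide uncertainty.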

Compound 3, half-life: > 50 h
Compound 3 was reported as a limit; the forecaster's own chance of this, stated with the estimate: 40%; middle value at least 2.5-fold (0.39 log units) from the limit.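

In this assay compound 3 gives > 50 h as a limit of the assay. Vinyl on this aromatic carbon gives an at least 2900-fold higher number from compound 2 to compound 3 (3.46 log units; beyond the scatter) and an at least 2900-fold higher number from compound 1 to compound 3 (3.46 log units; beyond the scatter) as the first readable steps of the series. The shared core alone therefore does not fix a short half-life, and the group at this place moves the reading from one limit of the assay to the other.

Going by these compounds, each step has a limit at both ends, so its true size stays open. On these data alone, whether an ethyl group or an amine at this place would last as long as vinyl also stays open.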